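Working notes: fluoro in place of hydrogen on compound 3

The compounds below may be only part of what the source reports. "The series", "measured", "known", "first", "only" and "open" are said of these compounds alone.

Measured in an ADME assay on MDBK cells (Bos taurus) for cytotoxicity, read by MTT assay, with a stated time of 96 h; on this read-out lower numbers stand for higher toxicity in this test and higher numbers for lower toxicity in this test:
- compound 1 `CC[C@H]1CC[C@H](c2ccc(NC(=S)Nc3cccc(C(F)(F)F)c3)cc2)CC1`: 9000 nM
- compound 2 `O=[N+]([O-])c1ccc(NC(=S)Nc2cccc(C(F)(F)F)c2)cc1`: 10000 nM
- compound 3 `FC(F)(F)c1cccc(NC(=S)Nc2ccccc2)c1`: 49000 nM

Compound 3 holds the highest number of the three, at 49000 nM. The unmeasured compound 4 `Fc1cccc(NC(=S)Nc2cccc(C(F)(F)F)c2)c1` differs from it by fluoro in place of hydrogen on an aromatic carbon. Within the data shown here, two measured steps bear on this change: a 5.4-fold higher number from compound 1 to compound 3 (0.74 log units; beyond the scatter) and a 4.9-fold higher number from compound 2 to compound 3 (0.69 log units; beyond the scatter). Both are modest, and both show the compound with hydrogen on the higher number. Among the measured compounds shown here, no measured step involves fluoro. In this assay the expected change is therefore toward a lower number and smaller than either of those steps, giving an estimated 1.8-fold lower number from compound 3 to compound 4 (0.24 log units; within the scatter). For compound 4 the estimate is 28000 nM, with an expected range of 11000 nM to 65000 nM.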

Compound 4, half-maximal cytotoxic concentration: 10000 nM
Beside the measured number, compound 4's estimate is 2.8-fold (0.45 log units) above it; measured number below the stated range.
By their numbers in this assay, from the lowest: compounds 1, 2 and 4 (each within the scatter of the next); then compound 3.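

In this assay, phenyl to 3-fluorophenyl gives a 4.9-fold lower number from compound 3 to compound 4 (0.69 log units; beyond the scatter), so a single fluoro atom on an aromatic carbon is enough to move the number beyond the scatter, by a modest step. Earlier, only the 4-ethylcyclohexyl and nitro replacements had shown a lower number than compound 3; compound 4 now joins compounds 1 and 2 in the lowest group, leaving compound 3 alone at the top. Nothing available explains this change.

From the compounds shown here alone, whether the step depends on where the fluoro sits on the ring remains open. Also open, going by these compounds, is whether chloro, methoxy or an amine at this position would give a similar number.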